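The compounds below may be only part of what the source reports. "The series", "measured", "known", "first", "only" and "open" are said of these compounds alone.

Among the compounds with values here, in a physicochemical assay for pharmacokinetics, read by fluorescence and HPLC, with a stated time of 24 h (on this read-out lower numbers stand for a shorter-lived compound and higher numbers for a longer-lived compound), compound 1 `CC(C)(C)C1=C(C(=O)O)N2C(=O)/C(=C/c3ccco3)C2O1` gives 0.22 h and compound 2 `COc1ccccc1/C=C1/C(=O)N2C(C(=O)O)=C(C(C)(C)C)OC12` gives 0.2 h, so compound 2 stands within the scatter of compound 1, the only other number. Compound 3 `COc1ccc(/C=C2/C(=O)N3C(C(=O)O)=C(C(C)(C)C)OC23)cc1` is still unmeasured and differs from compound 2 as follows: 4-methoxyphenyl in place of 2-methoxyphenyl on a double-bonded chain carbon bound to a double-bonded ring carbon. This places 4-methoxyphenyl in place of 2-methoxyphenyl on a double-bonded chain carbon bound to a double-bonded ring carbon. Within the data shown here, one measured step bears on the change: a 1.1-fold lower number from compound 1 to compound 2 (0.04 log units; within the scatter), with 2-methoxyphenyl in place of furan-2-yl at that same place. Among the measured compounds shown here, no measured pair compares the two methoxyphenyl groups directly, so the evidence is thin. No step beyond the scatter is expected in this assay, and no direction is favoured. The expected step is no change at the digits printed from compound 2 to compound 3 (within the scatter). The estimated half-life of compound 3 is 0.2 h, with an expected range from 0.1 h to 0.4 h.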

Compound 3, half-life: 0.2 h
The estimate for compound 3 equals the measured number at the digits printed; the range from low to high includes it.
By their numbers in this assay, from the lowest: compounds 2, 3 and 1 (each within the scatter of the next).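

In this assay the direct comparison of the two methoxyphenyl groups, 4-methoxyphenyl in place of 2-methoxyphenyl on a double-bonded chain carbon bound to a double-bonded ring carbon, gives no change at the digits printed from compound 2 to compound 3 (within the scatter) so the two cannot be told apart at this place. The second reading, a 1.1-fold lower number from compound 1 to compound 3 (0.04 log units; within the scatter) with 4-methoxyphenyl in place of furan-2-yl, means that all three groups at this place now stand within the scatter of one another. Nothing at hand accounts for this flat result.

The groups shown at this place are all aromatic rings, so whether an amine, a carboxylic acid or a longer chain there would also leave the half-life within the scatter stays open. Changes elsewhere on the shared core are equally open, since all three compounds carry it unchanged.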